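This account rests on a few compounds, and the source may have more. Where it says the series, first, only, none or still open, it means among the compounds named here.

Compound 1 `O=C(CCN1CCCCC1)N1CCC2(N3CCCC3)CC(c3ccccc3)C1C(c1ccccc1)C2` is measured in an ADME assay on L6 cells (Rattus norvegicus) for cytotoxicity (a lower number here means a stronger inhibitor, a higher number a weaker inhibitor), where compound 1 gives 108000 nM, the highest of the two numbers at hand. Going by the values given here, its only neighbour is compound 2 `CN1CCN(CC(=O)N2CCC3(N4CCCC4)CC(c4ccccc4)C2C(c2ccccc2)C3)CC1`, which in this assay gives 69100 nM; the step of a 1.6-fold lower number from compound 1 to compound 2 (0.19 log units; within the scatter) comes from a change on a saturated chain carbon bound to a carbonyl carbon. Compound 3 `CN(C)C12CCN(C(=O)CCN3CCCCC3)C(C(c3ccccc3)C1)C(c1ccccc1)C2` differs from compound 1 elsewhere: dimethylamino in place of pyrrolidin-1-yl on a saturated ring carbon. Among the compounds with values here, no measured step touches that ring position, so the one step at hand offers little guidance, and no shift beyond the scatter in this assay is expected. Compound 3 is therefore estimated at 108000 nM, between 45000 nM and 260000 nM, a step of no change at the digits printed from compound 1 to compound 3 (within the scatter).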

Compound 3, half-maximal inhibitory concentration: 128000 nM
For compound 3 the middle estimate is 1.2-fold (0.07 log units) below the measured one; low and high end bracket the measured number.
By their numbers in this assay, from the lowest: compounds 2, 1 and 3 (each within the scatter of the next).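

In this assay, going by these compounds alone, dimethylamino in place of pyrrolidin-1-yl on the saturated ring carbon gives a 1.2-fold higher number from compound 1 to compound 3 (0.07 log units; within the scatter), the first measured change at this position. Exchanging the five-membered ring of pyrrolidin-1-yl for dimethylamino, which has no ring, therefore leaves compound 1 and compound 3 indistinguishable in this read-out. Nothing available explains this result. Going by these compounds, whether morpholin-4-yl or a hydroxyl group on this ring carbon would move the number beyond the scatter remains open. So does whether this exchange would behave alike with the 4-methylpiperazin-1-yl side chain of compound 2.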